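Cyclopropyl for Methoxyphenyl on a Ring Amide Nitrogen

This account rests on a few compounds, and the source may have more. Where it says the series, first, only, none or still open, it means among the compounds named here.

Measured compounds:
- compound 1 `COc1cccc(N2C(=O)COc3ccc(-c4cnc(Cl)c(NS(=O)(=O)c5ccc(F)cc5)c4)cc32)c1`: > 40000 nM
- compound 2 `O=C1COc2ccc(-c3ccc(O)cc3)cc2N1`: > 40000 nM

In a functional assay on A-375 cells (Homo sapiens) for antiproliferative activity, read by MTT assay, with a stated time of 72 h (on this read-out lower numbers stand for stronger inhibition and higher numbers for weaker inhibition), compound 1 gives > 40000 nM, which is a limit of the assay rather than a measured number. Compound 2, which lacks the chloropyridine sulfonamide arm, also reaches only a limit in this assay, > 40000 nM. Both values sit at the limit of > 40000 nM in this assay, at which 2 of the 2 values shown sit, so compound 1 stands at the limit among the numbers shown, and no step between measured compounds can be read.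

Compound 3 `O=C1COc2ccc(-c3cnc(Cl)c(NS(=O)(=O)c4ccc(F)cc4)c3)cc2N1C1CC1` keeps the shared core and the sulfonamide arm of compound 1 and differs by cyclopropyl in place of 3-methoxyphenyl on an amide-type nitrogen in a ring. Among the compounds with values here, with no measured step to lean on, the direction of this change is open; the expected step is an at least 2.6-fold lower number from compound 1 to compound 3 (0.42 log units; beyond the scatter), carrying wide uncertainty in this assay. Compound 3 is expected to give about 15000 nM, within a range from 1500 nM to 40000 nM.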

Compound 3, half-maximal inhibitory concentration: 21800 nM
For compound 3 the middle estimate is 1.5-fold (0.16 log units) below the measured one, and the stated range covers the measured number.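

In this assay, compound 3 is the first compound shown to give a measured number rather than a limit, so the group on the amide-type nitrogen in a ring can now be linked to a readable result. Cyclopropyl in place of 3-methoxyphenyl gives an at least 1.8-fold lower number from compound 1 to compound 3 (0.26 log units; that floor lies within the scatter), so this floor alone does not establish a real gain, although the true step could be larger. Compound 1 and compound 2 each remain at a limit, not a number: the limit of > 40000 nM in this assay, at which 2 of the 3 values shown sit.

The compounds shown leave open how a plain methyl, a longer chain such as n-butyl, or a chain ending in an amine would behave on this nitrogen. They also leave open whether a ring is needed there at all.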